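Swapping 2-methoxyphenyl for 4-chlorophenyl on compound 1

The compounds below may be only part of what the source reports. "The series", "measured", "known", "first", "only" and "open" are said of these compounds alone.

Values so far in a functional assay on MCF7 cells (Homo sapiens) for cytotoxicity, with a stated time of 48 h (a higher number here means a weaker inhibitor, a lower number a stronger inhibitor), are these:
compound 1 `COc1cc(OC)c(C(=O)/C=C/c2ccccc2OC)c(OC)c1` gives 8900 nM
compound 2 `COc1cc(OC)c(C(=O)/C=C/c2ccccc2SC)c(OC)c1` gives 9300 nM
compound 3 `COc1cc(O)c(C(=O)/C=C/c2ccccc2OC)c(OC)c1` gives 10500 nM

Compound 1 has no separate standing among these numbers, since its value lies within the scatter of both others and the three cannot be ranked. The change leading to compound 4 `COc1cc(OC)c(C(=O)/C=C/c2ccc(Cl)cc2)c(OC)c1` is 4-chlorophenyl in place of 2-methoxyphenyl on a double-bonded chain carbon bound to a double-bonded chain carbon, counted as 4-chlorophenyl in place of 2-methoxyphenyl on a double-bonded chain carbon bound to a double-bonded chain carbon in full. Among the measured compounds shown here, two measured steps bear on it, and only in part. Methylsulfanyl in place of the methoxy gave a 1.0-fold higher number from compound 1 to compound 2 (0.02 log units; within the scatter) and hydrogen in place of methyl on an oxygen on an aromatic ring gave a 1.2-fold higher number from compound 1 to compound 3 (0.07 log units; within the scatter) as the second step. Both lie within the scatter. For the measured compounds named here, no measured compound carries 4-chlorophenyl, so the range must stay wide. In this assay no step beyond the scatter is expected, in either direction. The estimated step is a 1.1-fold lower number from compound 1 to compound 4 (0.05 log units; within the scatter) on this reasoning. For compound 4 the estimated value is 8000 nM with an expected range from 3000 nM to 20000 nM overall.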

Compound 4, half-maximal inhibitory concentration: 7500 nM
For compound 4 the middle estimate is 1.1-fold (0.03 log units) above the measured one; the measured number falls inside the stated range.
By their numbers in this assay, from the lowest: compounds 4, 1, 2 and 3 (each within the scatter of the next).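

In this assay, the whole group on the double-bonded chain carbon bound to a double-bonded chain carbon was exchanged without any step leaving the scatter: 4-chlorophenyl in place of 2-methoxyphenyl gives a 1.2-fold lower number from compound 1 to compound 4 (0.07 log units; within the scatter), and in place of 2-(methylsulfanyl)phenyl it gives a 1.2-fold lower number from compound 2 to compound 4 (0.09 log units; within the scatter). The earlier steps shown here had each altered a single small group, whereas here both the substituent and its printed ring number differ at once, and the values still cannot be ranked. Nothing measured speaks to what lies behind this flat result.

As far as these compounds go, whether a phenyl carrying an amine or a carboxylic acid, or a longer chain in place of the ring, would give a step beyond the scatter stays open. So does whether 4-chlorophenyl behaves the same way on the core of compound 3.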